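Replacing 6-(thiophen-3-yl)pyridin-3-yl with 2-aminophenyl

The source may report more compounds than this note shows. Statements on the series, on what has been measured and on what is new or still open speak of the compounds shown alone.

Values in a functional assay on HCT-116 cells (Homo sapiens) for inhibition, with a stated time of 72 h; on this read-out lower numbers stand for stronger inhibition and higher numbers for weaker inhibition:
Compound 1 `NC1CCC(Nc2nc(NCc3ccc(Br)cc3)c3ncn(C4CCCC4)c3n2)CC1`: 790 nM
Compound 2 `NC1CCC(Nc2nc(NCc3ccc(-c4cccs4)nc3)c3ncn(C4CCCC4)c3n2)CC1`: 97 nM
Compound 3 `NC1CCC(Nc2nc(NCc3ccc(-c4ccsc4)nc3)c3ncn(C4CCCC4)c3n2)CC1`: 145 nM

Two measured steps show where compound 3 stands. The first is a 1.5-fold higher number from compound 2 to compound 3 (0.17 log units; within the scatter) and the second is a 5.4-fold lower number from compound 1 to compound 3 (0.74 log units; beyond the scatter). Compound 3 therefore sits level with compound 2 and clearly under compound 1.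

Compound 4 `Nc1ccccc1CNc1nc(NC2CCC(N)CC2)nc2c1ncn2C1CCCC1` is still unmeasured. Its change from compound 3 is 2-aminophenyl in place of 6-(thiophen-3-yl)pyridin-3-yl on a saturated chain carbon bound to a nitrogen on an aromatic ring.

The most relevant evidence comes from steps at this same place. One is an 8.1-fold lower number from compound 1 to compound 2 (0.91 log units; beyond the scatter) and the other is a 5.4-fold lower number from compound 1 to compound 3 (0.74 log units; beyond the scatter). Compound 4 gives up the thiophene-bearing group and, like compound 1, carries a single ring of carbon only. Going by the values given here, no measured compound carries 2-aminophenyl, so its own contribution is unknown and the range must stay wide. A rise of similar size to those steps, back towards compound 1 at 790 nM, is the reasonable expectation.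

The expected result is a 5.5-fold higher number from compound 3 to compound 4 (0.74 log units; beyond the scatter) in this assay. For compound 4 the estimated value is 800 nM, with an expected range from 250 nM to 2500 nM.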

Compound 4, half-maximal inhibitory concentration: 2300 nM
For compound 4 the middle estimate is 2.9-fold (0.46 log units) below the measured one, within the range that was stated.
By their numbers in this assay, from the lowest: compounds 2 and 3 (each within the scatter of the next); then compound 1; then compound 4.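

In this assay, going by these compounds alone, changes at this place can be much larger than the earlier steps showed, with the loss of the two-ring thiophene-bearing groups giving the largest steps so far (a 16-fold higher number from compound 3 to compound 4 (1.20 log units; beyond the scatter) and a 24-fold higher number from compound 2 to compound 4 (1.37 log units; beyond the scatter)). Having a single ring of carbon only does not fix the result either, as 2-aminophenyl and 4-bromophenyl are also clearly apart (a 2.9-fold higher number from compound 1 to compound 4 (0.46 log units; beyond the scatter)), so the group carried on that ring matters too. Nothing measured here explains these differences.

The compounds shown leave open whether the higher number of compound 4 comes from the amine itself or from the absence of the second ring. A plain phenyl group, or a 6-phenylpyridin-3-yl group without any thiophene, would help to separate these two contributions.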